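The source may report more compounds than this note shows. Statements on the series, on what has been measured and on what is new or still open speak of the compounds shown alone.

Of the compounds shown here, three of one shared core have been measured in a functional assay on MDA-MB-231 cells (Homo sapiens) for cytotoxicity, read by MTT assay, with a stated time of 38 h; a lower number here means a stronger inhibitor, a higher number a weaker inhibitor. Compound 1 `CCN(CC)CCCCOc1c(-c2cc(OC)c(OC)c(OC)c2)oc2cc(OC)cc(OC)c2c1=O` gives 13000 nM; compound 2 `COc1cc(OC)c2c(=O)c(OCC(=O)N/N=C/c3ccc[nH]3)c(-c3cc(OC)c(OC)c(OC)c3)oc2c1` gives 3750 nM; compound 3 `COc1cc(OC)c2c(=O)c(OCCCCN3CCCC3)c(-c3cc(OC)c(OC)c(OC)c3)oc2c1` gives 10400 nM. Compound 2 thus has the lowest number of the three: the change from compound 1 to compound 2 brings a 3.5-fold lower number from compound 1 to compound 2 (0.54 log units; beyond the scatter), and from compound 2 to compound 3 the number moves a 2.8-fold higher number from compound 2 to compound 3 (0.44 log units; beyond the scatter). Between compound 1 and compound 3 the step is a 1.3-fold lower number from compound 1 to compound 3 (0.10 log units; within the scatter).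

Compound 4 `COc1cc(OC)c2c(=O)c(OCC(=O)N/N=C/c3ccc(C)cc3)c(-c3cc(OC)c(OC)c(OC)c3)oc2c1` keeps the hydrazone arm of compound 2 and changes only its terminal ring: 4-methylphenyl in place of 1H-pyrrol-2-yl on a carbon with a double bond to nitrogen. The two measured steps that touch compound 2 both exchange the whole arm for an amine-bearing chain, so neither tests a swap of one aromatic ring for another on the carbon with a double bond to nitrogen. What they show is that the hydrazone arm carries the lower number. Among the measured compounds shown here, with no step of the relevant kind, the estimate for compound 4 is a step of a 1.2-fold higher number from compound 2 to compound 4 (0.08 log units; within the scatter), not expected to go beyond the scatter. Compound 4 is therefore expected to give about 4500 nM in this assay, within 1500 nM to 13000 nM.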

Compound 4, half-maximal inhibitory concentration: 4570 nM
Compound 4: the middle estimate sits 1.0-fold (0.01 log units) below what was measured, within the range that was stated.
By their numbers in this assay, from the lowest: compounds 2 and 4 (each within the scatter of the next); then compounds 3 and 1 (each within the scatter of the next).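

The first direct test of the terminal ring on a carbon with a double bond to nitrogen gives a 1.2-fold higher number from compound 2 to compound 4 (0.09 log units; within the scatter) in this assay, so 4-methylphenyl and 1H-pyrrol-2-yl cannot be told apart here, even though only the latter carries a hydrogen-bond donor. The advantage of the hydrazone arm over the amine-bearing chains also holds with this second terminal ring, with a 2.3-fold lower number from compound 3 to compound 4 (0.36 log units; beyond the scatter) and a 2.8-fold lower number from compound 1 to compound 4 (0.45 log units; beyond the scatter), and no compound shown goes against it. Nothing available explains why the exchange of rings leaves the number within the scatter.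

Two terminal rings cannot show whether a pyridin-3-yl ring, a 4-nitrophenyl or a 4-carboxyphenyl on the same carbon would also stay within the scatter. On these data alone, it also remains open how much of the arm's advantage rests on its carbonyl or on the chain length.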